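This account rests on a few compounds, and the source may have more. Where it says the series, first, only, none or still open, it means among the compounds named here.

Values so far in an ADME assay (liver) for metabolic stability, with Liver microsome (Homo sapiens) as the target, read by LC-MS, using microsomes, with a stated time of 30 min, tested at 4 uM; a higher number here means that more of the compound is left, a lower number that less of the compound is left

Compound 1 `CCN1CCN(c2nc(C)nc3c2nc(-c2ccccc2Cl)n3C)CC1` gives 7%
Compound 2 `COCCn1c(-c2ccccc2Cl)nc2c(N3CCN(C(C)=O)CC3)nc(C)nc21` gives 35%
Compound 3 `Cc1nc(N2CCN(C)CC2)c2nc(-c3ccccc3C(F)(F)F)n(C3CCOCC3)c2n1` gives 24%

Compound 3 stands second highest of these three numbers, below compound 2 and above compound 1, with both gaps beyond the scatter. Compound 4 `Cc1nc(N2CCN(C)CC2)c2nc(-c3ccccc3C#N)n(C3CCOCC3)c2n1` is not yet measured. It differs from compound 3 by cyano in place of trifluoromethyl on an aromatic carbon (cyano in place of trifluoromethyl on an aromatic carbon, ortho to a large group). For the measured compounds named here, no measured pair shows this change, so the only anchor is compound 3 at 24% and the range stays wide. A modest rise in this assay is expected, estimated as a number 9 percentage points higher from compound 3 to compound 4 (within the scatter) with real uncertainty. For compound 4 the estimated value is 33% within an expected range of 14% to 58% at this stage.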

Compound 4, percent of the compound remaining: 20%
Compound 4: middle estimate off by 13 percentage points, on the high side, and the stated range covers the measured number.
By their numbers in this assay, from the lowest: compound 1; then compounds 4 and 3 (each within the scatter of the next); then compound 2.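

In this assay, for the compounds shown here, the first step at this aromatic carbon, 2-(trifluoromethyl)phenyl to 2-cyanophenyl, reads a number 4 percentage points lower from compound 3 to compound 4 (within the scatter) and so stays within the scatter. At this position, then, cyano in place of trifluoromethyl does not separate the pair in this read-out. No available measurement explains why the two groups read alike.

Open, going by these compounds, is whether a methoxy group or a carboxylic acid on this aromatic carbon would give a step beyond the scatter from compound 3. Also open, on these data alone, is whether cyano in place of trifluoromethyl reads the same with a different amine on the shared core.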